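Swapping a methoxy for a fluorophenyl on a terpene stilbene

This account rests on a few compounds, and the source may have more. Where it says the series, first, only, none or still open, it means among the compounds named here.

Measured compounds:
compound 1 `C=C[C@@](C)(/C=C/c1ccc(OC)cc1)CCC=C(C)C`, > 36600 nM
compound 2 `CC(C)=CCC[C@](C)(/C=C/c1ccc(O)cc1)/C=C/c1cccc(F)c1`, > 36600 nM

Compound 1 is a terpene-bearing stilbene carrying a methoxy on its aromatic ring. In a functional assay on SEM cells (Homo sapiens) for cytotoxicity, with a stated time of 72 h (a lower number here means that less compound is needed, a higher number that more compound is needed for the effect), compound 1 gives only a limit, > 36600 nM, and no number. Compound 2 likewise reaches only a limit, > 36600 nM, in this assay. Compound 1 therefore stands at the limit of > 36600 nM in this assay, at which 2 of the 2 values shown sit, and there is no measured value on which it can be ranked against compound 2.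

Compound 3 `C=C[C@@](C)(/C=C/c1ccc(-c2ccc(F)cc2)cc1)CCC=C(C)C` differs from compound 1 in one place: 4-fluorophenyl in place of methoxy on an aromatic carbon, placed para to a large group. Going by the values given here, no measured pair shows what such a change does in this assay, so the size and direction of the step are open. Since compound 1 only reaches a limit, the step from compound 1 to compound 3 is expected to be an at least 1.2-fold lower number from compound 1 to compound 3 (0.08 log units; that floor lies within the scatter), a modest move at most. Compound 3 is estimated at 30000 nM, within a range of 8000 nM to 100000 nM.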

Compound 3, half-maximal effective concentration: > 36600 nM
Compound 3: only a limit was reported; the forecaster's own chance of this, stated with the estimate: 55%; at least 1.2-fold (0.08 log units) between middle value and limit.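

Compound 3 gives only a limit, > 36600 nM, in this assay, and with compound 1 also at a limit, the step between them cannot be read; all the compounds shown sit at one value: the limit of > 36600 nM in this assay, at which 3 of the 3 values shown sit.

What the 4-fluorophenyl in place of methoxy does in this assay stays open, since the compounds shown offer no measured number to rank them by.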